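This account rests on a few compounds, and the source may have more. Where it says the series, first, only, none or still open, it means among the compounds named here.

Compound 1 `CN(CC(C)(C)C)CC1(O)CCN(CCCc2c[nH]c3ccc(-n4cnnc4)cc23)CC1` gives 1.8 nM in an assay on CHO cells with 5-hydroxytryptamine receptor 1D (Homo sapiens) as the target; on this read-out higher numbers stand for weaker inhibition and lower numbers for stronger inhibition.
Compound 2 `CC1(C)CCCN(CC2(O)CCN(CCCc3c[nH]c4ccc(-n5cnnc5)cc34)CC2)C1` gives 0.65 nM in this assay.

Compound 2 holds the lowest number of the two, and its nearest neighbour is compound 1, separated by the step of a 2.8-fold lower number from compound 1 to compound 2 (0.44 log units; beyond the scatter). Compound 3 `CC(=O)Nc1ccc(CNCC2(O)CCN(CCCc3c[nH]c4ccc(-n5cnnc5)cc34)CC2)cc1` differs from compound 2 in one place: (4-acetamidobenzyl)amino in place of 3,3-dimethylpiperidin-1-yl on a saturated chain carbon bound to a saturated ring carbon. Going by the values given here, only one measured step bears on this, the one from compound 1 to compound 2, which changed the same position and was modest in size. A step in the other direction, of about that size or somewhat larger, is expected here, a 3.1-fold higher number from compound 2 to compound 3 (0.49 log units; beyond the scatter). Compound 3 is therefore estimated at 2 nM, with a likely range from 0.5 nM to 8 nM.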

Compound 3, half-maximal inhibitory concentration: 11 nM
Estimate against measurement, compound 3: 5.5-fold (0.74 log units) below, outside the stated range (above it).
By their numbers in this assay, from the lowest: compound 2; then compound 1; then compound 3.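

Replacing 3,3-dimethylpiperidin-1-yl with (4-acetamidobenzyl)amino gives a 17-fold higher number from compound 2 to compound 3 (1.23 log units; beyond the scatter) in this assay, and replacing methyl(neopentyl)amino with the same group gives a 6.1-fold higher number from compound 1 to compound 3 (0.79 log units; beyond the scatter) in this assay. This position on a saturated chain carbon bound to a saturated ring carbon therefore allows a much larger change in the number than the earlier pair showed. Nothing available explains this rise.

The compounds leave open whether the benzyl part or the acetamido part goes with the rise. A plain benzylamino group at the same place would separate the two.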